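The source may hold more compounds than are shown below. What is called first, only, known or untested is meant among the compounds shown, and "the series" means these compounds.

Measured compounds:
- compound 1 `O=C1/C(=C\c2cccc(Oc3ccccc3)c2)c2ccccc2N1c1c(Cl)cccc1Cl`; in a functional assay on MCF7 cells (Homo sapiens) for cytotoxicity, read by MTT assay, with a stated time of 72 h (on this read-out lower numbers stand for an effect already at smaller amounts and higher numbers for an effect only at larger amounts of compound), compound 1 gives 100 ug/mL
- compound 2 `O=C1/C(=C\c2cccc(Br)c2)c2ccccc2N1c1c(Cl)cccc1Cl`; in this assay compound 2 gives 5 ug/mL
- compound 3 `Cc1ccc2nc(Cl)c(/C=C3\C(=O)N(c4c(Cl)cccc4Cl)c4ccccc43)cc2c1`; in this assay compound 3 gives > 100 ug/mL, which is a limit of the assay and not a number.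

Among the two numbers shown, compound 2 stands lowest, with compound 1 nearest at a far higher number. Among the compounds with values here, the one measured step, a 20-fold lower number from compound 1 to compound 2 (1.30 log units; beyond the scatter), is large, and it concerns the group on the aromatic carbon; compound 3 adds only (the limit of > 100 ug/mL in this assay, at which 1 of the 3 values shown sits).

Compound 4 `CN(C)c1ccc(/C=C2\C(=O)N(c3c(Cl)cccc3Cl)c3ccccc32)cc1` differs from compound 2 in one place: 4-(dimethylamino)phenyl in place of 3-bromophenyl on a double-bonded chain carbon bound to a double-bonded ring carbon. Within the data shown here, no measured step exchanges the whole aryl group at this position, so the step from compound 2 to compound 4 has no direct precedent; the only guide is that a single change at the aryl group moved this assay strongly once before. A rise is therefore expected, of uncertain size: a 4.0-fold higher number from compound 2 to compound 4 (0.60 log units; beyond the scatter). On that basis compound 4 is estimated at 20 ug/mL, with a range from 3 ug/mL to 100 ug/mL.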

Compound 4, concentration for half-maximal effect: > 100 ug/mL
Compound 4 was reported as a limit; the forecaster's own chance of this, stated with the estimate: 25%; middle value at least 5.0-fold (0.69 log units) away from the limit.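

In this assay, 4-(dimethylamino)phenyl in place of 3-bromophenyl gives an at least 20-fold higher number from compound 2 to compound 4 (1.30 log units; beyond the scatter), so exchanging the whole aryl group on this double-bonded chain carbon can shift the read-out as strongly as the earlier change of a single group on the ring. From the compounds shown here alone, for compound 4, > 100 ug/mL is a limit of the assay and not a number, so the true size of this step remains unknown. Compound 2 therefore remains the only one of these compounds with a low number, and the limit now recurs: the limit of > 100 ug/mL in this assay, at which 2 of the 4 values shown sit.

The compounds shown do not separate the effect of the dimethylamino group from that of its place on the phenyl ring. Going by these compounds, how a phenyl ring carrying a primary amine or a carboxylic acid would read in this assay also stays open.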